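The source may hold more compounds than are shown below. What is called first, only, known or untested is meant among the compounds shown, and "the series" means these compounds.

Compound 1 `O=C1/C(=C\c2ccc(F)cc2)c2ccccc2N1c1c(Cl)cccc1Cl` is one of three compounds built on a shared core. In a functional assay on KB cells (Homo sapiens) for cytotoxicity, read by MTT assay, with a stated time of 72 h (a higher number here means that more compound is needed for the effect, a lower number that less compound is needed), compound 1 gives 5 ug/mL, the second highest of the three numbers. Compound 2 `O=C1/C(=C\c2ccc(O)cc2)c2ccccc2N1c1c(Cl)cccc1Cl` gives 2 ug/mL, while compound 3 `O=C1/C(=C\c2cc3ccccc3nc2Cl)c2ccccc2N1c1c(Cl)cccc1Cl` gives 10 ug/mL, and the gap between compound 1 and compound 3 lies within the scatter. Compound 4 `O=C1/C(=C\c2cccc(Cl)c2)c2ccccc2N1c1c(Cl)cccc1Cl` has not yet been measured; it differs from compound 1 in one place: 3-chlorophenyl in place of 4-fluorophenyl on a double-bonded chain carbon bound to a double-bonded ring carbon. Going by the values given here, the only measured step, a 2.5-fold lower number from compound 1 to compound 2 (0.40 log units; beyond the scatter), concerns a different change, so nothing measured bears directly on this one. In this assay a step within the scatter is therefore expected, no change at the digits printed from compound 1 to compound 4 (within the scatter). Compound 4 is estimated to give 5 ug/mL, with a range from 2 ug/mL to 12 ug/mL.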

Compound 4, concentration for half-maximal effect: 2 ug/mL
Estimate against measurement, compound 4: 2.5-fold (0.40 log units) above; low and high end bracket the measured number.
By their numbers in this assay, from the lowest: compounds 2 and 4 (each within the scatter of the next); then compounds 1 and 3 (each within the scatter of the next).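

In this assay, this position responds to more than the hydroxy swap seen earlier: 3-chlorophenyl in place of 4-fluorophenyl gives a 2.5-fold lower number from compound 1 to compound 4 (0.40 log units; beyond the scatter). Replacing 4-hydroxyphenyl with 3-chlorophenyl gives no change at the digits printed from compound 2 to compound 4 (within the scatter), so two different groups at this place give the same printed number. Nothing available explains either step. Because the halogen and its ring position change together, the compounds shown leave open which one matters; 4-chlorophenyl and 3-fluorophenyl would separate them. On these data alone, how an amine or a carboxylic acid on this ring would read also remains open.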